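Spiro compounds on liver cells: the same limit twice

The compounds below may be only part of what the source reports. "The series", "measured", "known", "first", "only" and "open" are said of these compounds alone.

Compounds measured so far:
Compound 1 `N#CC1=C(N)Oc2c(N)cc3nc4ccccc4nc3c2C12C(=O)N(Cc1cnnn1-c1c(F)cccc1F)c1ccccc12` — > 50000 nM
Compound 2 `N#CC1=C(N)Oc2c(N)cc3nc4ccccc4nc3c2C12C(=O)N(Cc1cnnn1-c1cc(Cl)ccc1Cl)c1ccccc12` — > 50000 nM

Both compounds share one core and differ only in the aryl group on the triazole nitrogen. In an ADME assay on L02 cells (Homo sapiens) for antiproliferative activity, read by MTT assay, with a stated time of 48 h (a lower number here means a stronger inhibitor, a higher number a weaker inhibitor), compound 1 gives > 50000 nM, which is a limit of the assay and not a number. In this assay compound 2 gives > 50000 nM, again a limit and not a number. Because (the limit of > 50000 nM in this assay, at which 2 of the 2 values shown sit), the step that the two limits leave unreadable from compound 1 to compound 2 cannot be read, so the swap of halogenated phenyl groups tells nothing about size or direction.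

Compound 3 `COc1ccc(OC)c(-n2nncc2CN2C(=O)C3(C(C#N)=C(N)Oc4c(N)cc5nc6ccccc6nc5c43)c3ccccc32)c1` carries 2,5-dimethoxyphenyl in place of 2,5-dichlorophenyl on an aromatic nitrogen. Among the compounds with values here, no measured step covers a change of this kind; the only comparison available, from compound 1 to compound 2, is unreadable. The expectation for compound 3 therefore rests on both measured compounds sitting at the limit, and compound 3 is expected to sit there as well, with a step that the limit leaves unreadable from compound 2 to compound 3 expected to be no step beyond the scatter. Compound 3 is estimated at 70000 nM, within 30000 nM to 200000 nM, and most likely reported only as a limit.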

Compound 3, half-maximal inhibitory concentration: > 50000 nM
Compound 3 ended at the assay's limit; the forecaster's own chance of this, stated with the estimate: 85%; the middle value lies beyond the limit too.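

Within the data shown here, no step among compound 1, compound 2 and compound 3 can be read, since each result is a limit of the assay and not a number: the limit of > 50000 nM in this assay, at which 3 of the 3 values shown sit. The compounds shown leave open whether any group on this aromatic nitrogen would give a readable value in this assay, and how the three groups shown rank against one another.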